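This account rests on a few compounds, and the source may have more. Where it says the series, first, only, none or still open, it means among the compounds named here.

Compound 1 `CCCn1c(=O)c2nc(-c3cnn(Cc4cccc(C)c4)c3)[nH]c2n(CCC)c1=O` gives 48 nM in an assay on CHO cells for displacement of a labelled ligand from adenosine receptor A1 (Homo sapiens); a higher number here means a weaker inhibitor, a lower number a stronger inhibitor. This is the lowest of the two numbers in this assay. Compound 2 `CCCCn1c(=O)c2nc(-c3cnn(Cc4ccccc4)c3)[nH]c2n(CCCC)c1=O` gives 1400 nM in this assay, a gap beyond the usual scatter, though compound 2 differs from compound 1 in more than one place. For compound 3 `CCCn1c(=O)c2nc(-c3cnn(Cc4ccc(OC)c(C(F)(F)F)c4)c3)[nH]c2n(CCC)c1=O` this assay reports "not determined" (no result reported), so compound 3 has no number there. Compound 4 `CCCn1c(=O)c2nc(-c3cnn(Cc4ccccc4C(F)(F)F)c3)[nH]c2n(CCC)c1=O` carries 2-(trifluoromethyl)phenyl in place of 3-methylphenyl on a saturated chain carbon bound to an aromatic nitrogen. Among the measured compounds shown here, no step between measured compounds isolates this change, so the expectation rests on compound 1 alone. Compound 4 is expected to show a 2.1-fold higher number from compound 1 to compound 4 (0.32 log units; beyond the scatter), a modest move toward a higher number, near the edge of the scatter. The estimate for compound 4 in this assay is 100 nM, with a range from 25 nM to 400 nM.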

Compound 4, inhibition constant: 44 nM
Estimate against measurement, compound 4: 2.3-fold (0.36 log units) above; the measured number falls inside the stated range.
By their numbers in this assay, from the lowest: compounds 4 and 1 (each within the scatter of the next); then compound 2.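

On the saturated chain carbon bound to an aromatic nitrogen, 2-(trifluoromethyl)phenyl in place of 3-methylphenyl gives a 1.1-fold lower number from compound 1 to compound 4 (0.04 log units; within the scatter) in this assay, so the two groups cannot be told apart by this read-out. This position therefore accepts 10 heavy atoms as well as 7 with no change beyond the scatter, although the step alters both the substituent and its place on the ring. No measurement at hand explains this result.

The separate contributions of substituent and ring placement remain unresolved. Also open, as far as these compounds go, is whether an amine or a carboxylic acid at this position would keep a number in this range.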